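The source may hold more compounds than are shown below. What is called first, only, known or untested is meant among the compounds shown, and "the series" means these compounds.

Compound 2 `CCCc1c[nH]c2ccc(F)cc12` carries a propyl chain on the shared core. In an assay on isolated protein for inhibition of Myeloperoxidase (Homo sapiens), read by ELISA, with a stated time of 5 min (a lower number here means a stronger inhibitor, a higher number a weaker inhibitor), compound 2 gives only a limit, > 100 nM, and not a number; this is the limit of the assay, at which one of the two values sits (the limit of > 100 nM in this assay, at which 1 of the 2 values shown sits). Compound 1 `NC(=O)CCCCc1c[nH]c2ccc(F)cc12`, which carries a longer chain ending in an amide, gives 43 nM in this assay. For the measured compounds named here, the one measured step shows an at least 2.3-fold higher number from compound 1 to compound 2 (0.36 log units; beyond the scatter).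

Compound 3 `NC(=O)CCCc1c[nH]c2ccc(F)cc12` differs from compound 2 by carbamoyl in place of hydrogen on a saturated chain carbon, three bonds along the chain from an aromatic carbon. This puts an amide back onto the chain, one bond closer to the core than in compound 1. Because the step of an at least 2.3-fold higher number from compound 1 to compound 2 (0.36 log units; beyond the scatter) went in the weakening direction when the amide group left, the return of an amide is expected to lower the number in this assay, with a step of about an at least 1.6-fold lower number from compound 2 to compound 3 (0.22 log units; that floor lies within the scatter). Compound 3 is therefore estimated at 60 nM, between 20 nM and 300 nM.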

Compound 3, half-maximal inhibitory concentration: 18 nM
For compound 3 the middle estimate is 3.3-fold (0.52 log units) above the measured one; measured number outside the range, below it.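

In this assay, adding carbamoyl to the end of the propyl chain gives an at least 5.5-fold lower number from compound 2 to compound 3 (0.74 log units; beyond the scatter), which shows that the gain from an amide on this chain does not depend on the longer chain of compound 1. For the compounds shown here, the position of the amide also counts, since carbamoyl in place of carbamoylmethyl gives a 2.4-fold lower number from compound 1 to compound 3 (0.38 log units; beyond the scatter), a comparison between two amides that the earlier compounds could not offer. The size of the first step remains a floor, as the value of compound 2 is a limit and not a number: the limit of > 100 nM in this assay, at which 1 of the 3 values shown sits.

The compounds shown leave open whether the amide itself is needed, or whether a carboxylic acid or an amine in place of carbamoyl would serve as well. They also leave open whether a chain shorter still, carrying the same carbamoyl, would lower the number further.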